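Ring expansion on the amide nitrogen: expected solubility

The source may report more compounds than this note shows. Statements on the series, on what has been measured and on what is new or still open speak of the compounds shown alone.

Compound 1 `Cn1cc(-c2cnc3c(-c4csc(C(=O)N[C@@H]5CCC[C@H]5N)c4)cnn3c2)cn1` sits at the top of the two measured numbers in a physicochemical assay for solubility, at pH 7 (on this read-out lower numbers stand for lower solubility and higher numbers for higher solubility), where compound 1 gives 203000 nM. Going by the values given here, its only measured neighbour is compound 2 `Cn1cc(-c2cnc3c(-c4csc(C(=O)N[C@@H]5CCCC[C@H]5N)c4)cnn3c2)cn1`, which in this assay gives 193000 nM; the step of a 1.1-fold lower number from compound 1 to compound 2 (0.02 log units; within the scatter) lies within the scatter, so the two values cannot be ordered.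

Compound 3 `Cn1cc(-c2cnc3c(-c4csc(C(=O)N[C@@H]5CCCC[C@@H]5N)c4)cnn3c2)cn1` is not yet measured. Relative to compound 1 the change is a group of 7 heavy atoms (6 carbon, 1 nitrogen; one six-membered non-aromatic ring of carbon only) in place of a group of 6 heavy atoms (5 carbon, 1 nitrogen; one five-membered non-aromatic ring of carbon only), on an amide-type nitrogen. Among the compounds with values here, the one measured step that bears on it is the same exchange of a five-membered for a six-membered ring on the amide-type nitrogen, from compound 1 to compound 2, which moved the number by a 1.1-fold lower number from compound 1 to compound 2 (0.02 log units; within the scatter). Nothing in the two measured compounds points to a shift beyond the scatter for this kind of change, and the two entering groups share the same count of donors, acceptors and defined stereocentres.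

Compound 3 is therefore expected to stay close to compound 1, with an estimated step of a 1.1-fold lower number from compound 1 to compound 3 (0.03 log units; within the scatter) in this assay. The estimate for compound 3 is 190000 nM, with a range from 120000 nM to 320000 nM.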

Compound 3, solubility: 68000 nM
The estimate for compound 3 lay 2.8-fold (0.45 log units) above the measured number; the whole stated range lies above it.
By their numbers in this assay, from the lowest: compound 3; then compounds 2 and 1 (each within the scatter of the next).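

The size of the ring on the amide-type nitrogen does not settle the result on its own: in this assay the exchange for 2-aminocyclohexyl gives a 3.0-fold lower number from compound 1 to compound 3 (0.47 log units; beyond the scatter), whereas the earlier ring exchange gave a 1.1-fold lower number from compound 1 to compound 2 (0.02 log units; within the scatter). Inverting the drawn configuration at one saturated ring carbon, from R to S, gives a 2.8-fold lower number from compound 2 to compound 3 (0.45 log units; beyond the scatter), a step of nearly the same printed size as the one from the five-membered ring. At this position the number in this assay therefore depends on how the 2-aminocyclohexyl group is configured, and the gap within this pair can be tied to configuration alone because of one fact: the fact that compounds 2 and 3 differ only in the configuration as drawn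

Compound 1 is the only compound shown with the five-membered ring, so whether configuration counts in the same way for that ring remains open. Also open, on these data alone, are what in the changed configuration goes with the lower number and whether the same gap would appear with a hydroxyl group or a methylamino group in place of the ring amine, or with a seven-membered carbon ring.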